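This account rests on a few compounds, and the source may have more. Where it says the series, first, only, none or still open, it means among the compounds named here.

In an ADME assay on Akata cells (Homo sapiens) for cytotoxicity (on this read-out lower numbers stand for higher toxicity in this test and higher numbers for lower toxicity in this test), compound 1 `Nc1nc2c(ncn2/C=C2\C[C@@H]2[C@H](O)CO)c(=O)[nH]1` gives 67000 nM, compound 2 `Nc1ncnc2c1ncn2/C=C1\C[C@@H]1[C@H](O)CO` gives 57000 nM and compound 3 `Nc1ncnc2c1ncn2/C=C1/C[C@@H]1[C@H](O)CO` gives 50500 nM. Compound 1 therefore stands within the scatter of both other compounds, and the three values show no order. Compound 4 `Nc1nc2c(ncn2/C=C2/C[C@H]2[C@@H](O)CO)c(=O)[nH]1` is related to compound 1 by a change of configuration alone: the two compounds have the same atoms and bonds and differ only in configuration as drawn: 3 of 3 stereo elements differ; a stereocentre at a saturated ring carbon is drawn S in compound 1 and R in compound 4; a stereocentre at a saturated chain carbon is drawn S in compound 1 and R in compound 4; a double bond is drawn E in compound 1 and Z in compound 4. For the measured compounds named here, only one measured step bears on this change, and it covers the double bond alone, given (the fact that compounds 2 and 3 differ only in the configuration as drawn). That step is a 1.1-fold lower number from compound 2 to compound 3 (0.05 log units; within the scatter), which lies within the scatter. Going by the values given here, no measured step isolates either of the two stereocentres, so their contribution is unknown and the range must stay wide. Among the compounds with values here, with the double bond as the only guide, no shift beyond the scatter is expected in this assay, in either direction. The expected change is a 1.1-fold lower number from compound 1 to compound 4 (0.05 log units; within the scatter). For compound 4 the estimated value is 60000 nM, with an expected range from 30000 nM to 110000 nM.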

Compound 4, half-maximal cytotoxic concentration: 78000 nM
Compound 4: the middle estimate sits 1.3-fold (0.11 log units) below what was measured; the measured number falls inside the stated range.
By their numbers in this assay, from the lowest: compounds 3, 2, 1 and 4 (each within the scatter of the next).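

In this assay, changing all three stereo elements at once left the number within the scatter, with a 1.2-fold higher number from compound 1 to compound 4 (0.07 log units; within the scatter). The earlier compounds had shown this only for the double bond on its own, with a 1.1-fold lower number from compound 2 to compound 3 (0.05 log units; within the scatter), whereas this pair also changes the stereocentre at a saturated ring carbon and the stereocentre at a saturated chain carbon. The new step therefore shows that the combined change in configuration does not separate the two compounds in this test, and the sole structural difference between them is: the fact that compounds 1 and 4 differ only in the configuration as drawn

The compounds shown do not isolate either stereocentre, so separate effects that offset one another cannot be ruled out. They also leave open how a compound carrying an amine, a carboxylic acid or a longer chain would read in this test.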